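The source may report more compounds than this note shows. Statements on the series, on what has been measured and on what is new or still open speak of the compounds shown alone.

Working notes on the series. The three measured compounds are compound 1 `C/C=C/C(=O)N(Cc1ccc(OC)c([N+](=O)[O-])c1)c1cc(OC)c(OC)c(OC)c1`, compound 2 `CCC(=O)N(Cc1ccc(OC)c(O)c1)c1cc(OC)c(OC)c(OC)c1` and compound 3 `COc1ccc(N(Cc2cc(OC)c(OC)c(OC)c2)C(=O)CN=[N+]=[N-])cc1O`; a fourth, compound 4 `C/C=C/C(=O)N(Cc1ccc(OC)c(Cl)c1)c1cc(OC)c(OC)c(OC)c1`, is not yet measured. In a functional assay on HCT-116 cells (Homo sapiens) for inhibition, read by MTT assay, with a stated time of 48 h (on this read-out higher numbers stand for weaker inhibition and lower numbers for stronger inhibition), compound 1 gives 670 nM. On the same read-out compound 2 gives 61 nM and compound 3 gives 38800 nM. Compound 1 therefore stands second highest of the three numbers: its nearest neighbour is compound 2, whose number lies lower by a margin beyond the usual scatter, and its furthest is compound 3, whose number lies higher by a still wider margin, also beyond the scatter. Among the compounds with values here, no pair of measured compounds differs in a single place, so these pairs show only their values and no attributable change.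

The change from compound 1 to compound 4 is chloro in place of nitro on an aromatic carbon. Within the data shown here, with no measured step of this kind to lean on, the expectation for compound 4 in this assay is loosely anchored; the series spans a wide range, and compound 2 at 61 nM shows that a number well below that of compound 1 is reachable within the shared core. The expected step, a 2.2-fold lower number from compound 1 to compound 4 (0.35 log units; beyond the scatter), is a moderate move toward a lower number, though an outcome within the scatter would not surprise. Compound 4 is estimated at 300 nM, with a range from 80 nM to 1500 nM.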

Compound 4, half-maximal inhibitory concentration: 1420 nM
Beside the measured number, compound 4's estimate is 4.7-fold (0.68 log units) below it; the measured number falls inside the stated range.
By their numbers in this assay, from the lowest: compound 2; then compound 1; then compound 4; then compound 3.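

Chloro in place of nitro on an aromatic carbon, ortho to a methoxy group and meta to a large group, gives in this assay a 2.1-fold higher number from compound 1 to compound 4 (0.33 log units; beyond the scatter), the first change in the series that can be assigned to one place. With the rest of the structure held constant, this position responds to the exchange of nitro, with its 3 heavy atoms and 2 hydrogen-bond acceptors, for chloro, with 1 heavy atom and no hydrogen-bond acceptors, but the move is modest and the number stays in the nanomolar range. Nothing at hand bears on why the number shifts in this direction.

As far as these compounds go, a single exchange sets no trend for this position, so it remains open whether an amine, a fluoro group or a methyl group in the same place would give a number lower than that of compound 1, higher than that of compound 4, or one between them. Also open, from the compounds shown here alone, is whether the exchange of nitro for chloro would give a step of similar size and direction with a longer chain on the amide carbonyl.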